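A few compounds are considered here, and "the series" means these few. Any claim that something is new, unique, unknown or untested is made for them only; others in the source may bear on it.

Measured compounds:
- Compound 1 `COC(=O)c1ccc(CN2CCC[C@H](O[C@H](CO)c3cc(Cl)cc(Cl)c3)[C@@H]2c2ccccc2)c(C)c1` — in an assay on isolated protein for activation of cGMP-dependent protein kinase 1 (Homo sapiens), read by ADP-Glo, with stated times of 30 min and 2 h, in the presence of a further agent that is not named here (a higher number here means that more compound is needed for the effect, a lower number that less compound is needed), compound 1 gives 900 nM
- Compound 2 `Cc1cc(C(=O)O)ccc1CN1C(=O)CC[C@H](OCc2cc(Cl)cc(Cl)c2)[C@@H]1c1ccccc1` — in this assay compound 2 gives 169000 nM

Compound 1 stands at the lowest of the two numbers; compound 2 is the nearest, and its number is far higher, beyond the usual scatter. Within the data shown here, compound 2 differs from compound 1 in several places at once, so its two values show only that the pair sits far apart, not what any one change does.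

Compound 3 `Cc1cc(C(=O)O)ccc1C(=O)N1CCC[C@H](O[C@H](CO)c2cc(Cl)cc(Cl)c2)[C@@H]1c1ccccc1` is not yet measured. It differs from compound 1 in one place: a group of 12 heavy atoms (9 carbon, 3 oxygen; one six-membered aromatic ring of carbon only) in place of a group of 12 heavy atoms (10 carbon, 2 oxygen; one six-membered aromatic ring of carbon only), on an amine nitrogen in a ring. The group that leaves carries a methyl ester on its aromatic ring; the group that enters carries a carboxylic acid and joins the ring nitrogen through a carbonyl, so the ring nitrogen becomes part of an amide.

Among the measured compounds shown here, with no single-change step available, the size of this step can only be guessed. For the measured compounds named here, the expectation is a moderate rise in the number, beyond the scatter, since compound 2, the only other compound with a carboxylic acid and a carbonyl on that nitrogen, gives 169000 nM. The step from compound 1 to compound 3 is estimated as a 4.4-fold higher number from compound 1 to compound 3 (0.65 log units; beyond the scatter). Compound 3 is expected to give 4000 nM, with a range from 600 nM to 30000 nM.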

Compound 3, half-maximal effective concentration: > 200000 nM
Compound 3 ended at the assay's limit; the forecaster's own chance of this, stated with the estimate: 10%; at least 50-fold (1.69 log units) between middle value and limit.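

In this assay, among these compounds, the change on the amine nitrogen in the ring gives an at least 220-fold higher number from compound 1 to compound 3 (2.34 log units; beyond the scatter), a large step and the first change in one place at this position: the methyl ester on the aromatic ring gives way to a carboxylic acid, and the link to the ring nitrogen becomes a carbonyl, which makes that nitrogen part of an amide. Compound 3 gives > 200000 nM, which is a limit of the assay and not a number. The step is therefore a lower bound, so this position clearly does not tolerate the change as a whole, but how much further the true value lies cannot be read: the limit of > 200000 nM in this assay, at which 1 of the 3 values shown sits.

The single step combines two alterations, the ester becoming an acid and the link becoming a carbonyl, so the compounds shown do not tell how much of the rise belongs to each. Open questions are how a carboxylic acid joined through a plain methylene link, a methyl ester joined through a carbonyl, or a primary amide on the same aromatic ring would behave at this position.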